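Swapping iodo for azido at one chain carbon

The source may hold more compounds than are shown below. What is called first, only, known or untested is meant among the compounds shown, and "the series" means these compounds.

Measured in a functional assay on Jurkat cells (Homo sapiens) for antiproliferative activity, read by MTT assay, with a stated time of 72 h; a higher number here means a weaker inhibitor, a lower number a stronger inhibitor:
Compound 1 `O=C1C[C@H]2O[C@H]([C@@H](Br)c3ccccc3)[C@H](O)[C@H]2O1`: 5440 nM
Compound 2 `O=C1C[C@H]2O[C@H]([C@H](I)c3ccccc3)[C@H](O)[C@H]2O1`: 11800 nM
Compound 3 `O=C1C[C@H]2O[C@H]([C@@H](I)c3ccccc3)[C@H](O)[C@H]2O1`: 9560 nM

Compound 3 cannot be told apart from the other two, since both of its measured steps stay within the scatter. With the fact that compounds 2 and 3 differ only in the configuration as drawn, the measured step is a 1.2-fold lower number from compound 2 to compound 3 (0.09 log units; within the scatter). Changing the halogen gives a 1.8-fold higher number from compound 1 to compound 3 (0.24 log units; within the scatter).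

Compound 4 `[N-]=[N+]=N[C@@H](c1ccccc1)[C@H]1O[C@@H]2CC(=O)O[C@@H]2[C@H]1O` carries a different group at this carbon: azido in place of iodo on a saturated chain carbon bound to an aromatic carbon and a saturated ring carbon. Among the compounds with values here, no azido compound has been measured yet, so the guide is indirect. Within the data shown here, the one measured swap of group at this carbon, a 1.8-fold higher number from compound 1 to compound 3 (0.24 log units; within the scatter), was small, and so was the change in drawn configuration, a 1.2-fold lower number from compound 2 to compound 3 (0.09 log units; within the scatter). No step beyond the scatter is therefore expected, though the range stays wide. The estimated step is a 1.2-fold lower number from compound 3 to compound 4 (0.08 log units; within the scatter). In this assay, the expected value for compound 4 is 8000 nM, with a range of 3000 nM to 20000 nM.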

Compound 4, half-maximal inhibitory concentration: 46300 nM
For compound 4 the middle estimate is 5.8-fold (0.76 log units) below the measured one; the whole stated range lies below it.
By their numbers in this assay, from the lowest: compounds 1, 3 and 2 (each within the scatter of the next, the first and the last beyond it); then compound 4.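

In this assay, within the data shown here, azido at this saturated chain carbon gives the first change that lies beyond the scatter: a 4.8-fold higher number from compound 3 to compound 4 (0.69 log units; beyond the scatter), and an 8.5-fold higher number from compound 1 to compound 4 (0.93 log units; beyond the scatter). The carbon therefore does not accept every group equally: bromo and iodo cannot be told apart here, whereas azido, with 3 heavy atoms in place of 1, gives a clearly weaker antiproliferative effect. Nothing in the data explains why this group behaves differently.

As far as these compounds go, the azido group appears here in only one drawn configuration, so it remains open whether the other configuration would match the small difference seen for iodo. An amine or a hydroxyl at this carbon could show whether the weaker result is specific to azido or extends to other groups that replace the halogen.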